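The compounds below may be only part of what the source reports. "The series", "measured", "known", "first", "only" and "open" are said of these compounds alone.

Of the compounds shown here, two have been tested in an ADME assay on RAW264.7 cells (Mus musculus) for cytotoxicity, read by MTT assay, with a stated time of 48 h; a lower number here means that less compound is tolerated, a higher number that more compound is tolerated. Compound 1, `C#CCN(c1nc(-c2ccccc2)no1)C1CCCCC1`, is the smaller of the two. In this assay compound 1 gives 32.1 ug/mL. Compound 2, `CC(=O)OC[C@H]1O[C@H](OC[C@@H](Cn2cc(CN(c3nc(-c4ccc(Cl)cc4)no3)C3CCCCC3)nn2)OC(C)=O)C=C[C@@H]1OC(C)=O`, carries the same cyclohexyl amine on the shared core but adds a long acetylated sugar chain through a triazole linker and a chlorine on the aromatic ring. In this assay compound 2 gives 35.5 ug/mL, a number that sits within the usual scatter of the number for compound 1, so the two compounds cannot be told apart on these data.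

Compound 3, `CC(=O)OC[C@H]1O[C@H](OC[C@@H](Cn2cc(CN(c3nc(-c4ccccc4)no3)C3CCCCC3)nn2)OC(C)=O)C=C[C@@H]1OC(C)=O`, is not yet measured. It differs from compound 2 in one place: hydrogen in place of chloro on an aromatic carbon. Among the compounds with values here, no measured pair in this set shows what removing this chlorine does. Within the data shown here, with only two compounds at hand, no step beyond the scatter is expected in this assay, and the number is estimated to remain close to that of compound 2 because compound 2 gives 35.5 ug/mL. The expected step from compound 2 to compound 3 is a 1.0-fold lower number from compound 2 to compound 3 (0.02 log units; within the scatter). Compound 3 is expected to give about 34 ug/mL, within a range from 17 ug/mL to 68 ug/mL.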

Compound 3, half-maximal cytotoxic concentration: 28.6 ug/mL
The estimate for compound 3 lay 1.2-fold (0.08 log units) above the measured number; low and high end bracket the measured number.
By their numbers in this assay, from the lowest: compounds 3, 1 and 2 (each within the scatter of the next).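

Within the data shown here, this pair is the first to differ in one place only, so it isolates the chloro group on an aromatic carbon, para to a large group. In this assay, going from 4-chlorophenyl to phenyl gives a 1.2-fold lower number from compound 2 to compound 3 (0.09 log units; within the scatter), so on this long acetylated sugar chain the chlorine can be replaced by hydrogen without a difference that can be told apart from the spread of repeated measurements. Nothing available explains this result, and one pair cannot show whether it would hold in other compounds.

Open, as far as these compounds go, is whether other groups at this position, such as a methoxy group, an amine or a carboxylic acid, would also leave the number within the scatter, as a single swap of chlorine for hydrogen says nothing about them. Also open, from the compounds shown here alone, is whether the same swap would read the same way on the smaller compound 1, which carries neither the triazole linker nor the sugar chain.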